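Swapping Trifluoromethyl for Dichloro on the Phenoxy Ring

The compounds below may be only part of what the source reports. "The series", "measured", "known", "first", "only" and "open" are said of these compounds alone.

Of the compounds shown here, three sharing one core have been tested in an ADME assay on MRC5 cells (Homo sapiens) for cytotoxicity, read by fluorescence and resazurin assay, with a stated time of 3 days; on this read-out lower numbers stand for stronger inhibition and higher numbers for weaker inhibition. Compound 1 `Cc1cccc(Oc2cccc(CN3CCC(n4cc(C)c(=O)[nH]c4=O)CC3)c2)c1` carries a methyl on an aromatic carbon; in this assay compound 1 gives only a limit, > 64000 nM. Compound 2 `Cc1cn(C2CCN(Cc3cccc(Oc4cccc(F)c4)c3)CC2)c(=O)[nH]c1=O` carries a fluoro at that carbon; in this assay compound 2 likewise gives only a limit, > 64000 nM. Among the measured compounds shown here, compound 3 `Cc1cn(C2CCN(Cc3cccc(Oc4cccc(C(F)(F)F)c4)c3)CC2)c(=O)[nH]c1=O` carries a trifluoromethyl there, and in this assay compound 3 gives 12400 nM, the only actual number among the three. Compounds 1 and 2 instead sit at the limit (the limit of > 64000 nM in this assay, at which 2 of the 3 values shown sit). Both readable steps run toward compound 3: an at least 5.1-fold lower number from compound 1 to compound 3 (0.71 log units; beyond the scatter) and an at least 5.1-fold lower number from compound 2 to compound 3 (0.71 log units; beyond the scatter).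

Compound 4 `Cc1cn(C2CCN(Cc3cccc(Oc4cc(Cl)cc(Cl)c4)c3)CC2)c(=O)[nH]c1=O` has not yet been measured. Its change from compound 3 is 3,5-dichlorophenyl in place of 3-(trifluoromethyl)phenyl on an oxygen on an aromatic ring. For the measured compounds named here, no measured step covers chloro on this ring; the two known steps show only that trifluoromethyl went with a lower number than methyl or fluoro. With nothing pointing either way, compound 4 is expected to land near compound 3, the step of a 1.2-fold higher number from compound 3 to compound 4 (0.08 log units; within the scatter) not clearly beyond the scatter. Compound 4 is therefore estimated at 15000 nM, with a likely range from 4000 nM to 64000 nM.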

Compound 4, half-maximal inhibitory concentration: 6730 nM
For compound 4 the middle estimate is 2.2-fold (0.35 log units) above the measured one; the range from low to high includes it.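

In this assay, the step from the trifluoromethyl ring to the ring with two chloro groups is a 1.8-fold lower number from compound 3 to compound 4 (0.27 log units; within the scatter), so compound 3 and compound 4 cannot be told apart, and at this place on the oxygen a second kind of ring now gives a real number. Set against the rings that gave none, 3,5-dichlorophenyl brings an at least 9.5-fold lower number from compound 2 to compound 4 (0.97 log units; beyond the scatter) and an at least 9.5-fold lower number from compound 1 to compound 4 (0.97 log units; beyond the scatter), which means that 3-(trifluoromethyl)phenyl is no longer the only group here that separates from fluoro and methyl. Both of these sizes are minimum figures, not true sizes, because compound 1 and compound 2 stop at a limit of the assay and not at a number: the limit of > 64000 nM in this assay, at which 2 of the 4 values shown sit.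

As far as these compounds go, it remains open whether a single chloro on this ring would read like compound 4 or stay at the limit like compound 2, so the part played by the second chloro cannot be separated out. Also open, from the compounds shown here alone, is how a ring bearing a nitrile, a methoxy group or a carboxylic acid would read in this assay.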